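Swapping a Hydroxyphenyl for Naphthyl on a Shared Core

A few compounds are considered here, and "the series" means these few. Any claim that something is new, unique, unknown or untested is made for them only; others in the source may bear on it.

Two compounds share one core and differ only in the aromatic group hanging from its double-bonded chain carbon. Compound 1 `CN(C)c1ccc(/C=C2\S/C(=N\c3csc(-c4ccc(Cl)cc4)c3)NC2=O)cc1` carries a dimethylaminophenyl group there, and in a functional assay on SW-620 cells (Homo sapiens) for cytotoxicity, read by MTT assay, with a stated time of 72 h (on this read-out lower numbers stand for stronger inhibition and higher numbers for weaker inhibition), compound 1 gives 800 nM. Compound 2 `O=C1N/C(=N/c2csc(-c3ccc(Cl)cc3)c2)S/C1=C\c1ccc(O)cc1` carries a 4-hydroxyphenyl group instead; in this assay compound 2 is recorded as "not determined" (no result reported), so it offers no fixed point on this read-out.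

Compound 3 `O=C1N/C(=N/c2csc(-c3ccc(Cl)cc3)c2)S/C1=C\c1ccc2ccccc2c1` is the next step: naphthalen-2-yl in place of 4-hydroxyphenyl on a double-bonded chain carbon bound to a double-bonded ring carbon. Since compound 2 has no value, the size of this step cannot be measured, and any expectation for compound 3 has to lean on compound 1 alone. Naphthalen-2-yl is a larger group than either the dimethylaminophenyl or the 4-hydroxyphenyl, and nothing here shows how the shared core tolerates such a change, so the direction is open; a shift of modest size in this assay in either direction, or none beyond the scatter, would all be unsurprising.

Because compound 1 gives 800 nM, compound 3 is expected to give about 1500 nM, with a plausible range from 300 nM to 8000 nM.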

Compound 3, half-maximal inhibitory concentration: > 50000 nM
Compound 3 was reported as a limit; the forecaster's own chance of this, stated with the estimate: 20%; middle value at least 33-fold (1.52 log units) away from the limit.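

In this assay, naphthalen-2-yl in place of 4-(dimethylamino)phenyl gives an at least 62-fold higher number from compound 1 to compound 3 (1.79 log units; beyond the scatter), so the group on the double-bonded chain carbon bound to a double-bonded ring carbon matters greatly for this read-out. Compound 3 sits at a limit of the assay, not at a number: the limit of > 50000 nM in this assay, at which 1 of the 3 values shown sits. Before this result, compound 1 at 800 nM was the only value for this position, which showed that one aromatic group there was compatible with a measured effect but not how much depended on that group.

Steps involving compound 2 cannot be read, and so 4-hydroxyphenyl adds no further point at this position. Going by these compounds, it also stays open whether the large step goes with the second aromatic ring of naphthalen-2-yl or with the loss of the dimethylamino group, since both changes come together in this one step, and a plain phenyl group, a 4-aminophenyl group or a 4-methoxyphenyl group at this place would be needed to pull the two apart.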